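Changing the group on the carbonyl of compound 1

This account rests on a few compounds, and the source may have more. Where it says the series, first, only, none or still open, it means among the compounds named here.

In a functional assay, with a stated time of 30 min, in the absence of a further agent (on this read-out lower numbers stand for stronger inhibition and higher numbers for weaker inhibition), compound 1 `O=C(COc1ccccc1)Nc1nnc(-c2cccc(O)c2O)s1` gives 16600 nM as the lowest of three numbers, which makes it the strongest inhibitor so far. Compound 2 `O=C(COc1ccccc1)Nc1nnc(-c2ccc(O)c(O)c2)s1` gives 36100 nM and compound 3 `O=C(Nc1nnc(-c2ccc(O)c(O)c2)s1)C1CCCCC1` gives 37300 nM on the same read-out.

Compound 4 `Cc1ccc(C(=O)Nc2nnc(-c3cccc(O)c3O)s2)cc1` has not been measured yet. It keeps the core of compound 1 but carries 4-methylphenyl in place of phenoxymethyl on a carbonyl carbon.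

The closest evidence is a swap at that same place. Cyclohexyl in place of phenoxymethyl gave a 1.0-fold higher number from compound 2 to compound 3 (0.01 log units; within the scatter) and this lies within the scatter. That swap was measured with 3,4-dihydroxyphenyl, however, so it may not carry over exactly. The other measured step gave a 2.2-fold higher number from compound 1 to compound 2 (0.34 log units; beyond the scatter) with 3,4-dihydroxyphenyl in place of 2,3-dihydroxyphenyl, a change that compound 4 does not make.

No step beyond the scatter is therefore expected in this assay and the estimate means a 1.1-fold higher number from compound 1 to compound 4 (0.04 log units; within the scatter) as the expected step. Compound 4 is expected at 18000 nM with an estimated range from 7000 nM to 45000 nM as its upper end.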

Compound 4, half-maximal inhibitory concentration: 27100 nM
For compound 4 the middle estimate is 1.5-fold (0.18 log units) below the measured one; the range from low to high includes it.
By their numbers in this assay, from the lowest: compounds 1, 4, 2 and 3 (each within the scatter of the next, the first and the last beyond it).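

In this assay, for the compounds shown here, 4-methylphenyl in place of phenoxymethyl on a carbonyl carbon gives a 1.6-fold higher number from compound 1 to compound 4 (0.21 log units; within the scatter) and so provides the first reading of a swap at this place with 2,3-dihydroxyphenyl on the shared core. Cyclohexyl gave a 1.0-fold higher number from compound 2 to compound 3 (0.01 log units; within the scatter) with 3,4-dihydroxyphenyl instead, so neither of these two replacements of phenoxymethyl moves the number beyond the scatter, and compound 1 is not separated from compound 4 in this assay. The oxygen and the hydrogen-bond acceptor counted in phenoxymethyl are absent from 4-methylphenyl, yet no measurement here explains this outcome.

All the groups compared at this place are carbon rings, with or without a linking oxygen. As far as these compounds go, an amine or a carboxylic acid on the carbonyl carbon therefore remains open, as does a longer chain.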